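A few compounds are considered here, and "the series" means these few. Any claim that something is new, unique, unknown or untested is made for them only; others in the source may bear on it.

Of the compounds shown here, three have so far been measured in a functional assay on PC-3 cells (Homo sapiens) for inhibition, read by MTT assay, with a stated time of 48 h; a higher number here means a weaker inhibitor, a lower number a stronger inhibitor. Compound 1 `O=C(/C=C/c1cccc([N+](=O)[O-])c1)c1ccc[nH]1` gives 23000 nM, compound 2 `O=C(/C=C/c1ccccc1Cl)c1ccco1` gives 14000 nM, and compound 3 `CN(C)c1ccc(/C=C/C(=O)c2ccco2)cc1` gives 13000 nM. The number for compound 3 lies within the usual scatter of both others, so repeat measurements alone could account for the gaps and these three cannot be ranked. Compound 4 `O=C(/C=C/c1ccccc1)c1ccco1` differs from compound 3 at a single place, with hydrogen in place of dimethylamino on an aromatic carbon. Going by the values given here, no measured pair shows this change, so the expectation rests only on how closely the three values agree, and no step beyond the scatter is expected in this assay. The estimate for compound 4 is 15000 nM, with an expected range from 6000 nM to 40000 nM.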

Compound 4, half-maximal inhibitory concentration: > 100000 nM
Compound 4 gave a limit, no number (the forecaster's own chance of this, stated with the estimate: 10%); middle value at least 6.6-fold (0.82 log units) away from the limit.
By their numbers in this assay, from the lowest: compounds 3, 2 and 1 (each within the scatter of the next). At a limit, above all of these: compound 4.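

In this assay compound 4 gives a limit, not a number: the limit of > 100000 nM in this assay, at which 1 of the 4 values shown sits. Hydrogen in place of dimethylamino on an aromatic carbon brings an at least 7.6-fold higher number from compound 3 to compound 4 (0.88 log units; beyond the scatter), and hydrogen in place of chloro on an aromatic carbon brings an at least 7.1-fold higher number from compound 2 to compound 4 (0.85 log units; beyond the scatter). Going by these compounds alone, these are the first single-place comparisons, and they show that with either group compound 3 and compound 2 keep a measured value in this assay, while with hydrogen compound 4 does not.

Still open, on these data alone, is whether an amino group or a methoxy group on that aromatic carbon would also keep a measured value.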